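The source may hold more compounds than are shown below. What is called first, only, known or untested is meant among the compounds shown, and "the series" means these compounds.

Compound 1 `COc1cc(OC)cc(-n2cc(-c3ccc(O)c(OC)c3)nn2)c1` and compound 2 `COc1cc(-c2cn(-c3cc(OC)c(OC)c(OC)c3)nn2)ccc1O` share one core, and compound 3 `COc1ccc(-c2cn(-c3ccc(OC)cc3)nn2)cc1` carries another; the difference between the two cores is not broken down here. In a functional assay on MDA-MB-231 cells (Homo sapiens) for cytotoxicity, read by MTT assay (on this read-out higher numbers stand for weaker inhibition and lower numbers for stronger inhibition), compound 1 gives 10000 nM. For compound 2 this assay reports only a limit, > 10000 nM. The change methoxy in place of hydrogen on an aromatic carbon therefore gives a step of a number no lower from compound 1 to compound 2 (the limit leaves the size open). For compound 3 this assay again reports only a limit, > 100 nM. Compound 4 `COc1ccc(-c2cn(-c3ccc(OC)c(OC)c3)nn2)cc1` has not been measured; it differs from compound 3 by methoxy in place of hydrogen on an aromatic carbon. Among the compounds with values here, this is the same kind of change as the one from compound 1 to compound 2, but not the same: there the methoxy entered ortho to two methoxy groups and para to a large group, here it enters ortho to a methoxy group and meta to a large group. Since compound 3 shows only a limit, > 100 nM, and the step from compound 1 to compound 2, a number no lower from compound 1 to compound 2 (the limit leaves the size open), has no readable size, the step from compound 3 to compound 4 is expected to be a step that the limit leaves unreadable from compound 3 to compound 4. In this assay compound 4 is estimated at 5000 nM, most likely between 500 nM and 30000 nM.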

Compound 4, half-maximal inhibitory concentration: > 10000 nM
Compound 4 gave a limit, no number; the forecaster's own chance of this, stated with the estimate: 50%; middle value at least 2.0-fold (0.30 log units) from the limit.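

Compound 3 and compound 4 are both reported only as limits, so no size can be read for the step between them. The compounds shown leave open how strongly compound 2, compound 3 and compound 4 act in this assay, and whether methoxy in place of hydrogen on an aromatic carbon changes the read-out at all.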